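This account rests on a few compounds, and the source may have more. Where it says the series, first, only, none or still open, it means among the compounds named here.

Measured so far:
Compound 1 `C/C(=C\c1nn(CCC(C)C)c(=O)c(C2=NS(=O)(=O)c3cc(NS(C)(=O)=O)ccc3N2)c1O)C(F)(F)F` — 0.167 h
Compound 2 `CC(C)(C)CCn1nc(-c2cccs2)c(O)c(C2=NS(=O)(=O)c3cc(NS(C)(=O)=O)ccc3N2)c1=O` — > 1 h

Both compounds were run in an in vitro ADME assay on microsomes from liver (Homo sapiens) for metabolic stability, tested at 5 uM; a lower number here means that the compound disappears faster, a higher number that the compound lasts longer. Compound 1 gives 0.167 h. For compound 2 this assay reports only a limit, > 1 h, not a number; this is the limit of > 1 h in this assay, at which 1 of the 2 values shown sits. Compound 2 therefore stands at the top edge of what has been seen here, and compound 1 shows a clearly lower number, though the two differ in more than one place, so nothing about any single change can be read from the gap between them.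

Compound 3 `CS(=O)(=O)Nc1ccc2c(c1)S(=O)(=O)N=C(c1c(O)c(-c3cccs3)nn(CCC3CCCCC3)c1=O)N2` has not yet been tested. It differs from compound 2 in one place: cyclohexyl in place of tert-butyl on a saturated chain carbon, two bonds along the chain from an aromatic nitrogen. Among the measured compounds shown here, no pair of measured compounds isolates this change, so there is no measured step to lean on.

The expectation for compound 3 is a modest fall from compound 2, a step of an at least 1.2-fold lower number from compound 2 to compound 3 (0.09 log units; that floor lies within the scatter), close to the edge of the usual scatter rather than far beyond it. Compound 3 is accordingly expected to give 0.8 h in this assay, with a likely range from 0.3 h to 2 h.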

Compound 3, half-life: > 1 h
Compound 3: only a limit was reported; the forecaster's own chance of this, stated with the estimate: 40%; at least 1.2-fold (0.09 log units) between middle value and limit.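

Compound 3 gives only a limit in this assay and compound 2 does as well, so the size of the step between them cannot be read: the limit of > 1 h in this assay, at which 2 of the 3 values shown sit.

On these data alone, what stays open is how long either compound actually lasts, and whether cyclohexyl in place of tert-butyl shifts that number at all.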